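From a Chlorophenyl Amine to a Benzyl Amine

The source may report more compounds than this note shows. Statements on the series, on what has been measured and on what is new or still open speak of the compounds shown alone.

Compound 1 `CCOC(=O)CN(Cc1ccccc1)c1nc(NCc2ccccc2)ncc1[N+](=O)[O-]` gives 21000 nM in a functional assay on HepG2 cells (Homo sapiens) for antiproliferative activity, read by MTT assay, with a stated time of 48 h; on this read-out lower numbers stand for stronger inhibition and higher numbers for weaker inhibition.
Compound 2 `CCOC(=O)CN(Cc1ccccc1)c1nc(NCc2cccc(OC)c2)ncc1[N+](=O)[O-]` gives 33600 nM in this assay.
Compound 3 `COC(=O)CN(C)c1nc(Nc2ccc(Cl)cc2)ncc1[N+](=O)[O-]` gives 49800 nM in this assay.

Compound 3 shows the highest of the three numbers; its gap to compound 2 stays within the usual scatter of repeated measurements, while its gap to compound 1 lies beyond it.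

Compound 4 `COC(=O)CN(C)c1nc(NCc2ccccc2)ncc1[N+](=O)[O-]` differs from compound 3 in one place: benzyl in place of 4-chlorophenyl on a nitrogen on an aromatic ring. For the measured compounds named here, the only measured step with a single change, a 1.6-fold higher number from compound 1 to compound 2 (0.20 log units; within the scatter), concerns a methoxy on a different ring and says nothing about swapping an aryl group for a benzyl group on the amine nitrogen. Going by the values given here, compounds 1 and 3 differ at three places at once, so their two values show only that the benzylamino compounds seen so far carry lower numbers than the chlorophenylamino compound, without telling which change is responsible.

Among the compounds with values here, with no direct precedent, compound 4 is expected to move only modestly toward a lower number, as a 1.7-fold lower number from compound 3 to compound 4 (0.22 log units; within the scatter), and the estimate in this assay for compound 4 is 30000 nM, with a range from 12000 nM to 80000 nM.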

Compound 4, half-maximal inhibitory concentration: > 100000 nM
Compound 4: only a limit was reported (the forecaster's own chance of this, stated with the estimate: 10%); middle value at least 3.3-fold (0.52 log units) from the limit.
By their numbers in this assay, from the lowest: compounds 1, 2 and 3 (each within the scatter of the next, the first and the last beyond it). At a limit, above all of these: compound 4.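

Compound 4 gives only a limit in this assay, not a number: the limit of > 100000 nM in this assay, at which 1 of the 4 values shown sits.

The step, an at least 2.0-fold higher number from compound 3 to compound 4 (0.30 log units; that floor lies within the scatter), therefore fixes only a floor, and the true size of the move cannot be read from it. Even so, it is the first direct test at this position, and it shows that replacing 4-chlorophenyl with benzyl on this nitrogen brings no lower number on the background of compound 3, so the benzylamino group alone is not enough to produce one. That turns attention to the other two places where compounds 1 and 3 differ: the benzyl or methyl group on the other nitrogen, and the ethyl or methyl ester.

Going by these compounds, the step changes two things together, the chlorine and the extra carbon that links the ring to the nitrogen, so it remains open which of them matters. A plain phenyl or a 4-chlorobenzyl group on this nitrogen would pull the two apart, and a benzyl group on the other nitrogen of compound 4 would show whether that place accounts for the lower number of compound 1.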